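Series notes: ethoxy to trifluoromethoxy step

The compounds below may be only part of what the source reports. "The series", "measured", "known", "first", "only" and "open" are said of these compounds alone.

Measured compounds:
compound 1 `Cc1ccc2nc(C(=O)Nc3c(F)cc(-c4cccc(F)c4)cc3F)c(C)c(O)c2c1` — 16.2%
compound 2 `CCOc1ccc2nc(C(=O)Nc3c(F)cc(-c4cccc(F)c4)cc3F)c(C)c(O)c2c1` — 4.56%

In a functional assay on A-375 cells (Homo sapiens) for antiproliferative activity, read by MTT assay, with a stated time of 24 h, tested at 3.7 ug/mL (on this read-out higher numbers stand for a stronger effect at the one concentration tested and lower numbers for a weaker effect), compound 1 gives 16.2% and compound 2 gives 4.56%. For the measured compounds named here, compound 2 stands lowest of the two numbers; its nearest neighbour is compound 1, and the single known step, a number 11.6 percentage points lower from compound 1 to compound 2 (beyond the scatter), is beyond the scatter.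

Compound 3 `Cc1c(C(=O)Nc2c(F)cc(-c3cccc(F)c3)cc2F)nc2ccc(OC(F)(F)F)cc2c1O` is not yet measured. It differs from compound 2 in one place: trifluoromethyl in place of ethyl on an oxygen on an aromatic ring. Going by the values given here, no measured step touches this kind of change; the one step known, from methyl to ethoxy on an aromatic carbon, alters a different part of the substituent and gives no direct guide to swapping ethyl for trifluoromethyl on the same oxygen. Both measured numbers are low, and compound 2 sits at the bottom, so the expectation for compound 3 rests on compound 2 alone.

For compound 3 the estimate in this assay is 8%, with a range from -6% to 24%. The step this estimate means, a number 3.4 percentage points higher from compound 2 to compound 3 (within the scatter), is expected to stay within the scatter, with no direction called.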

Compound 3, a percentage reported as inhibition, at one concentration (the size of the read-out at that concentration, not a potency): 2.06%
The estimate for compound 3 lay 5.9 percentage points above the measured number; the range from low to high includes it.
By their numbers in this assay, from the lowest: compounds 3 and 2 (each within the scatter of the next); then compound 1.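

In this assay trifluoromethyl in place of ethyl on the oxygen gives a number 2.5 percentage points lower from compound 2 to compound 3 (within the scatter) and so leaves the ethoxy and trifluoromethoxy compounds unseparated on this read-out. Trifluoromethoxy in place of methyl on the aromatic carbon gives a number 14.1 percentage points lower from compound 1 to compound 3 (beyond the scatter) and thereby adds a second oxygen-bearing substituent, after ethoxy, that stands beyond the scatter from the methyl of compound 1. Compound 1 therefore remains the highest of the three in this assay, while the change on the oxygen itself shows no measurable effect here, although three compounds at a single concentration set no general rule for this position. No measurement that could account for these numbers is at hand.

From the compounds shown here alone, it remains open whether an amine, a carboxylic acid or a longer alkoxy chain at this position would stay with compound 2 and compound 3 or move towards compound 1. Going by these compounds, it also remains open whether compound 2 and compound 3 would separate at a higher concentration or after a longer exposure, since the present read-out gives the size of the effect at one concentration and no potency.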